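The source may report more compounds than this note shows. Statements on the series, on what has been measured and on what is new or still open speak of the compounds shown alone.

Compound 3 `CC/N=C(\S)NCCCCn1nc(-c2ccccc2)ccc1=O` gives the lowest of the two numbers in a functional assay on the whole organism (stomach) with Rattus norvegicus as the target (a lower number here means that less compound is needed, a higher number that more compound is needed for the effect), namely 37.2 mg/kg. Its nearest neighbour is compound 1 `CC/N=C(/NC#N)NCCCn1nc(-c2ccccc2)ccc1=O`, which in this assay gives 78.3 mg/kg; that step is a 2.1-fold lower number from compound 1 to compound 3 (0.32 log units; beyond the scatter). Compound 2 `C=CCNC(=S)NCCCCn1nc(-c2ccccc2)ccc1=O` reaches only the limit of this assay, > 100 mg/kg. Compound 4 `C/N=C(\NC#N)NCCCCn1nc(-c2ccccc2)ccc1=O` differs from compound 3 by a group of 6 heavy atoms (3 carbon, 3 nitrogen; no ring) in place of a group of 5 heavy atoms (3 carbon, 1 nitrogen, 1 sulfur; no ring), on an amine nitrogen. Among the compounds with values here, the change bearing on it is the one that took compound 1 to compound 3, where a group of the same kind as the one now entering was replaced by a sulfur-bearing group; the move to compound 4 runs that change backwards, so a modest rise in the dose is expected. The expected step is therefore a 1.9-fold higher number from compound 3 to compound 4 (0.27 log units; within the scatter). Compound 4 is thus estimated at 70 mg/kg, with a range from 35 mg/kg to 140 mg/kg.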

Compound 4, dose for half-maximal effect: 32.4 mg/kg
For compound 4 the middle estimate is 2.2-fold (0.33 log units) above the measured one, outside the stated range (below it).
By their numbers in this assay, from the lowest: compounds 4 and 3 (each within the scatter of the next); then compound 1. At a limit, above all of these: compound 2.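

In this assay, the group of 6 heavy atoms (3 carbon, 3 nitrogen) on the amine nitrogen cannot be told apart from the sulfur-bearing group it replaces, a 1.1-fold lower number from compound 3 to compound 4 (0.06 log units; within the scatter), so the lower dose of compound 3 does not depend on sulfur. Two further steps hold for this sulfur-free group: a 2.4-fold lower number from compound 1 to compound 4 (0.38 log units; beyond the scatter), and an at least 3.0-fold lower number from compound 2 to compound 4 (0.48 log units; beyond the scatter). The second rests on a limit, that of compound 2: the limit of > 100 mg/kg in this assay, at which 1 of the 4 values shown sits.

The compounds shown leave open whether a longer chain would lower the dose further. They also leave open how an amine or a carboxylic acid on the amine nitrogen would fare.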